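Ring Nitrogen Enters Where Fluorophenyl Leaves

This account rests on a few compounds, and the source may have more. Where it says the series, first, only, none or still open, it means among the compounds named here.

Three compounds share one core and differ only in the aryl group attached to it. In an assay (Rattus norvegicus) for inhibition of Fatty-acid amide hydrolase 1 (Homo sapiens) (a higher number here means a weaker inhibitor, a lower number a stronger inhibitor), compound 1 `Nc1cccc(-c2cnc(C(=O)CCCCCCc3ccccc3)o2)c1` gives 19 nM, compound 2 `O=C(CCCCCCc1ccccc1)c1ncc(-c2cccc(O)c2)o1` gives 50 nM, and compound 3 `O=C(CCCCCCc1ccccc1)c1ncc(-c2ccc(F)cc2)o1` gives 62 nM. Compound 3 thus holds the highest of the three numbers, though its gap to compound 2, a 1.2-fold higher number from compound 2 to compound 3 (0.09 log units; within the scatter), lies within the scatter, while the step of a 3.3-fold higher number from compound 1 to compound 3 (0.51 log units; beyond the scatter) lies beyond it, as does a 2.6-fold higher number from compound 1 to compound 2 (0.42 log units; beyond the scatter).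

Compound 4 `Cc1cccnc1-c1cnc(C(=O)CCCCCCc2ccccc2)o1` is not yet measured. It differs from compound 3 in one place: 3-methylpyridin-2-yl in place of 4-fluorophenyl on an aromatic carbon. The measured steps that bear on this change are the two that swapped the same aryl group, a 3.3-fold higher number from compound 1 to compound 3 (0.51 log units; beyond the scatter) and a 1.2-fold higher number from compound 2 to compound 3 (0.09 log units; within the scatter), one modest and one within the scatter. Going by the values given here, no measured compound carries a ring nitrogen in this group, so there is nothing to show how the added acceptor behaves. The step of a 1.1-fold higher number from compound 3 to compound 4 (0.05 log units; within the scatter) is therefore expected to be small, with no confident direction. Compound 4 is estimated at 70 nM in this assay, with a range from 25 nM to 200 nM.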

Compound 4, inhibition constant: 15 nM
For compound 4 the middle estimate is 4.7-fold (0.67 log units) above the measured one; measured number below the stated range.
By their numbers in this assay, from the lowest: compounds 4 and 1 (each within the scatter of the next); then compounds 2 and 3 (each within the scatter of the next).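

Going by these compounds alone, the earlier compounds carried only all-carbon aryl rings at this place, next to the ring oxygen of the shared core, so 3-methylpyridin-2-yl is the first group here with a ring nitrogen, and the change proves far from neutral: in this assay there is a 4.1-fold lower number from compound 3 to compound 4 (0.62 log units; beyond the scatter) when it replaces 4-fluorophenyl and a 3.3-fold lower number from compound 2 to compound 4 (0.52 log units; beyond the scatter) when it replaces 3-hydroxyphenyl. Against the 3-aminophenyl group there is a 1.3-fold lower number from compound 1 to compound 4 (0.10 log units; within the scatter), which lies within the scatter, so a group with no hydrogen-bond donors can match the level that compound 1 had set among the earlier compounds, whereas 4-fluorophenyl, also without donors, did not. Nothing available explains why this group gives the lower number.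

The ring nitrogen and the methyl enter together, so these four compounds cannot assign the step to either one; a plain pyridin-2-yl and a phenyl ring bearing only a methyl would separate them. On these data alone, it also remains open whether other ring nitrogen groups, such as a pyrimidine, behave in the same way at this place, or whether the step holds with a shorter chain on the carbonyl.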